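This account rests on a few compounds, and the source may have more. Where it says the series, first, only, none or still open, it means among the compounds named here.

The series shares one core, seen in compound 1 `Nc1c(-c2nc3ccccc3[nH]2)cc(-c2ccccc2)n1-c1ccccn1` and compound 2 `Nc1c(-c2nc3ccccc3[nH]2)cc(-c2ccccc2)n1-c1cccc(Cl)c1`, which differ only on an aromatic nitrogen, where compound 2 carries 3-chlorophenyl in place of pyridin-2-yl. In a functional assay on A549 cells (Homo sapiens) for cytotoxicity, read by resazurin assay, with a stated time of 72 h (a lower number here means a stronger inhibitor, a higher number a weaker inhibitor), compound 1 gives 8000 nM and compound 2 gives 7000 nM; the step of a 1.1-fold lower number from compound 1 to compound 2 (0.06 log units; within the scatter) is within the scatter, so the two numbers cannot be told apart, and compound 2 sits at the same level as its only comparator. Compound 3 `Nc1c(-c2nc3ccccc3[nH]2)cc(-c2ccccc2)n1-c1nc2ccccc2[nH]1` keeps this core and changes the same nitrogen again: 1H-benzimidazol-2-yl in place of 3-chlorophenyl on an aromatic nitrogen. Within the data shown here, the only measured step at this nitrogen, a 1.1-fold lower number from compound 1 to compound 2 (0.06 log units; within the scatter), exchanged one ring for another and moved the number by no more than the scatter; no measured step introduces a 1H-benzimidazol-2-yl group or a hydrogen-bond donor at this site, so the present change is uncharted. Among the measured compounds shown here, with that single step as the only guide, compound 3 is expected to stay near compound 2, a step of no change at the digits printed from compound 2 to compound 3 (within the scatter) that should not exceed the scatter. The estimate for compound 3 in this assay is 7000 nM, with a range from 2500 nM to 20000 nM.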

Compound 3, half-maximal inhibitory concentration: 7700 nM
Estimate against measurement, compound 3: 1.1-fold (0.04 log units) below; the range from low to high includes it.
By their numbers in this assay, from the lowest: compounds 2, 3 and 1 (each within the scatter of the next).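

At the aromatic nitrogen of the shared core, this assay does not separate 1H-benzimidazol-2-yl from 3-chlorophenyl: the step of a 1.1-fold higher number from compound 2 to compound 3 (0.04 log units; within the scatter) lies within the scatter, as does the step of a 1.0-fold lower number from compound 1 to compound 3 (0.02 log units; within the scatter), which replaces pyridin-2-yl. The earlier pair compared single six-membered aromatic rings, whereas the entering 1H-benzimidazol-2-yl group adds a five-membered aromatic ring with 2 hetero atoms and carries 9 heavy atoms and 1 hydrogen-bond donor, against 7 heavy atoms and 0 hydrogen-bond donors in 3-chlorophenyl, and the number stays at the same level, so across these three compounds neither difference appears in the read-out. Nothing on hand bears on why the three groups read alike.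

On these data alone, all three groups on this nitrogen are aromatic rings, so it remains open whether an aliphatic amine, a carboxylic acid or a longer alkyl chain at the same place would move the number beyond the scatter. Equally open, as far as these compounds go, is how the number responds to changes at the ring atoms that bear the phenyl group and the amino group.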